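Compound 3 at the limit, and one added group

A few compounds are considered here, and "the series" means these few. Any claim that something is new, unique, unknown or untested is made for them only; others in the source may bear on it.

In a functional assay on RAW264.7 cells (Mus musculus) for inhibition, read by Griess assay, with stated times of 3 h and 24 h (on this read-out lower numbers stand for stronger inhibition and higher numbers for weaker inhibition), the measured compounds read as follows, each value being a limit:
Compound 1 `C=C1CC[C@H]2[C@@](C)(CCC(=O)N[C@@]2(C)COC(=O)c2ccccc2)[C@@H]1/C=C/C1=CCOC1=O` gives > 50000 nM
Compound 2 `C=C1CC[C@H]2[C@@](C)(CCC(=O)N[C@@]2(C)COC(=O)[C@H](N)CC(C)C)[C@@H]1/C=C/C1=CCOC1=O` gives > 50000 nM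
Compound 3 `C=C1CC[C@H]2[C@@](C)(CC[C@@H](O)[C@@]2(C)NC=O)[C@@H]1/C=C/C1=CCOC1=O` gives > 50000 nM

Compound 3 stands at > 50000 nM and this is a limit, not a number. Every measured compound sits there (the limit of > 50000 nM in this assay, at which 3 of the 3 values shown sit), so nothing ranks them.

Compound 4 `C=C1CC[C@H]2[C@@](C)(CC[C@@H](OC(=O)[C@H](N)CC(C)C)[C@@]2(C)NC=O)[C@@H]1/C=C/C1=CCOC1=O` differs from compound 3 in one place ((1-amino-3-methylbutyl)carbonyl in place of hydrogen on an oxygen on a saturated carbon): hydroxy becomes ((1-amino-3-methylbutyl)carbonyl)oxy, on a saturated carbon.

Among the measured compounds shown here, no measured step shows this exact change. The nearest one, a step that the two limits leave unreadable from compound 1 to compound 2, also brings in a 1-amino-3-methylbutyl group, but it gives no size to carry over. Compound 2 carries that group and still reads > 50000 nM as a limit. No shift beyond the usual scatter is therefore expected in this assay, and no direction can be argued. The estimated step is a number no higher from compound 3 to compound 4 (the limit leaves the size open) and a further limit reading is the likeliest result. For compound 4 the expected value is 50000 nM (estimated range 15000 nM to 100000 nM).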

Compound 4, half-maximal inhibitory concentration: > 50000 nM
Compound 4 ended at the assay's limit (the forecaster's own chance of this, stated with the estimate: 75%); the middle value lies on the limit itself.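

The step between compound 3 and compound 4 cannot be read: both values are limits, not numbers. The compounds shown leave open which change to the shared core, if any, would give a measurable value in this assay, where every reading so far stands at one limit: the limit of > 50000 nM in this assay, at which 4 of the 4 values shown sit.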